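Working notes: an amine exchange on the shared core

The compounds below may be only part of what the source reports. "The series", "measured", "known", "first", "only" and "open" are said of these compounds alone.

- compound 1 `CCCC(=O)N(c1ccccc1)C1CCCC1N(C)C`: 10 mg/kg
- compound 2 `C=CCNC1CCCC1N(C(=O)CC)c1ccc(Cl)c(Cl)c1`: 3 mg/kg

Both values come from a functional assay on the whole organism for antagonist activity, with Mus musculus as the target; on this read-out lower numbers stand for an effect already at smaller amounts and higher numbers for an effect only at larger amounts of compound. Compound 2 reads 3 mg/kg and compound 1 reads 10 mg/kg, so compound 2 holds the lower of the two numbers, with a gap beyond the usual scatter. Among the measured compounds shown here, these two compounds differ in more than one place, so no single-change step has been measured.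

Compound 3 `CCC(=O)N(c1ccc(Cl)c(Cl)c1)C1CCCC1N(C)CCCN(C)C`, not yet measured, carries (3-(dimethylamino)propyl)(methyl)amino in place of allylamino on a saturated ring carbon. For the measured compounds named here, with no measured step to go on, the size of this change can be judged only from the structures. A move toward a higher number in this assay is expected, although a result within the scatter remains possible. The estimated change is a 2.7-fold higher number from compound 2 to compound 3 (0.43 log units; beyond the scatter). Compound 3 is estimated at 8 mg/kg, with an expected range of 2 mg/kg to 30 mg/kg.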

Compound 3, dose for half-maximal effect: 10 mg/kg
Compound 3: the middle estimate sits 1.3-fold (0.10 log units) below what was measured; measured number inside the range.
By their numbers in this assay, from the lowest: compound 2; then compounds 1 and 3 (each within the scatter of the next).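

Among the compounds shown here, this is the first single-change step: in this assay, (3-(dimethylamino)propyl)(methyl)amino in place of allylamino on a saturated ring carbon gives a 3.3-fold higher number from compound 2 to compound 3 (0.52 log units; beyond the scatter), so the number at this position depends on the amine it carries. The step is modest, and the larger group with its second nitrogen and no hydrogen-bond donor still gives a measurable dose for half-maximal effect. No supporting data bear on what drives this step.

The exchange alters the chain, the substitution on nitrogen and the double bond at once, so the step does not separate these features. On these data alone, whether a plain dimethylamino group or a shorter 2-(dimethylamino)ethyl chain at this carbon would read nearer compound 2 or compound 3 remains open.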